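The compounds below may be only part of what the source reports. "The series", "measured", "known", "first", "only" and "open" are said of these compounds alone.

Two members of the series carry numbers in a functional assay on DU-145 cells (Homo sapiens) for inhibition, read by sulforhodamine B assay, with a stated time of 48 h; a lower number here means a stronger inhibitor of growth, a higher number a weaker inhibitor of growth. Compound 1 `COc1cc(-c2nn(-c3cccc(NC(=O)Nc4cc(C(F)(F)F)cc(C(F)(F)F)c4)c3)cc2-c2ccncc2)ccc1Cl` gives 1310 nM in this assay, and compound 2 `COc1cc(-c2nn(-c3cccc(NC(=O)c4cccc(C(F)(F)F)c4)c3)cc2-c2ccncc2)ccc1Cl` gives 1760 nM. Compound 2 holds the higher of the two numbers, but its gap to compound 1 sits within the scatter, so the pair cannot be ordered. Compound 3 `COc1cc(-c2nn(-c3cccc(NC(=O)Nc4ccc(Cl)c(Cl)c4)c3)cc2-c2ccncc2)ccc1Cl` has no number yet in this assay. It differs from compound 2 in one place: (3,4-dichlorophenyl)amino in place of 3-(trifluoromethyl)phenyl on a carbonyl carbon, so the (3-(trifluoromethyl)phenyl)carbonyl of compound 2 becomes a (3,4-dichlorophenyl)carbamoyl in compound 3. Among the compounds with values here, no measured pair shows a change of this kind, so the size of the step rests on the two known values alone. Compound 3 is expected to give 1200 nM in this assay, with a range from 400 nM to 3600 nM. That estimate means a step of a 1.5-fold lower number from compound 2 to compound 3 (0.17 log units; within the scatter), expected to be small, within the scatter or leaning slightly toward a lower number.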

Compound 3, concentration for 50% growth inhibition: 1520 nM
Compound 3: the middle estimate sits 1.3-fold (0.10 log units) below what was measured; measured number inside the range.
By their numbers in this assay, from the lowest: compounds 1, 3 and 2 (each within the scatter of the next).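

In this assay, within the data shown here, the exchange of 3-(trifluoromethyl)phenyl for (3,4-dichlorophenyl)amino on the carbonyl carbon gives a 1.2-fold lower number from compound 2 to compound 3 (0.06 log units; within the scatter) as the first single-place step. This position therefore accepts a (3,4-dichlorophenyl)carbamoyl in place of a (3-(trifluoromethyl)phenyl)carbonyl, with its added hydrogen-bond donor, without a readable shift in the number, something the earlier pair could not show. Nothing measured here speaks to why the number holds.

The step changes the atom on the carbonyl carbon and the ring substituents together, so (3-(trifluoromethyl)phenyl)amino on the same carbon would be needed to separate the two. On these data alone, whether the number also holds with a saturated amine such as piperidin-1-yl in this place remains open.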